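The source may hold more compounds than are shown below. What is called first, only, known or untested is meant among the compounds shown, and "the series" means these compounds.

Three compounds built on the shared core of compound 1 `CC(C)(Oc1ccc(Cl)cc1)C(=O)Nc1nc(-c2ccccc2)n[nH]1` have been measured in an assay on CHO cells for displacement of a labelled ligand from adenosine receptor A3 (Homo sapiens), read by scintillation counting, with a stated time of 60 min; on this read-out higher numbers stand for weaker inhibition and lower numbers for stronger inhibition. Compound 1 gives 500 nM, compound 2 `Cc1cccc(OCC(=O)Nc2nc(-c3ccccc3)n[nH]2)c1` gives 1500 nM and compound 3 `O=C(COc1ccc2c(c1)CCC2)Nc1nc(-c2ccccc2)n[nH]1` gives 2200 nM. Compound 2 holds the second highest of the three numbers: its gap to compound 3 lies within the usual scatter, while compound 1 stands clearly lower, beyond that scatter. Compound 4 `O=C(COCc1ccccc1)Nc1nc(-c2ccccc2)n[nH]1` remains to be measured in this assay. It keeps the same atoms as compound 2, joined differently: benzyl in place of 3-methylphenyl on an oxygen on a saturated carbon. For the measured compounds named here, no measured pair shows such a rearrangement, so only a small step is expected, leaning toward a higher number but possibly within the scatter: a 1.7-fold higher number from compound 2 to compound 4 (0.22 log units; within the scatter). Compound 4 is therefore expected to give 2500 nM, between 800 nM and 8000 nM.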

Compound 4, inhibition constant: 4600 nM
For compound 4 the middle estimate is 1.8-fold (0.26 log units) below the measured one; measured number inside the range.
By their numbers in this assay, from the lowest: compound 1; then compounds 2 and 3 (each within the scatter of the next); then compound 4.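

In this assay, rearranging the same atoms from 3-methylphenyl to benzyl on an oxygen on a saturated carbon gives a 3.1-fold higher number from compound 2 to compound 4 (0.49 log units; beyond the scatter), so this position responds to how the group is joined. The two groups match in heavy atoms, aromatic ring, hydrogen-bond donors and acceptors, and charge, yet the inhibition becomes weaker. Nothing available explains this shift.

Going by these compounds, it remains open how a longer chain, such as 2-phenylethyl, would behave at this position. On these data alone, the effect of an amine on the benzyl ring also remains unknown.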